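The source may hold more compounds than are shown below. What is called first, only, known or untested is meant among the compounds shown, and "the series" means these compounds.

Measured in a physicochemical assay for solubility, in phosphate buffer, at pH 7.4; a lower number here means a less soluble compound, a higher number a more soluble compound:

- Compound 1 `CC(=O)N[C@@H]1CCC[C@H](C(=O)Nc2cc(-c3cnn4c3CCCC4)ccn2)C1` gives 730000 nM
- Compound 2 `CC(=O)N[C@@H]1CCC[C@H](C(=O)Nc2cc(-c3cnn4c3CCC4)c(Cl)cn2)C1` gives 160000 nM

Compound 2 holds the lower of these two numbers, and the gap to compound 1 lies beyond the scatter. Compound 3 `CC(=O)N[C@@H]1CCC[C@H](C(=O)Nc2cc(-c3cnn4c3OCCC4)c(Cl)cn2)C1` differs from compound 2 by a group of 9 heavy atoms (6 carbon, 2 nitrogen, 1 oxygen; one five-membered aromatic ring with 2 hetero atoms, one six-membered non-aromatic ring with 2 hetero atoms) in place of a group of 8 heavy atoms (6 carbon, 2 nitrogen; one five-membered non-aromatic ring with 1 hetero atom, one five-membered aromatic ring with 2 hetero atoms), on an aromatic carbon. The change sits on an aromatic carbon, ortho to a chloro group. Among the measured compounds shown here, no pair of measured compounds isolates this change, so the data offer no direct guide to it. The step expected in this assay is a 1.1-fold lower number from compound 2 to compound 3 (0.06 log units; within the scatter), with no movement beyond the scatter in either direction. The estimated value for compound 3 is 140000 nM, with an expected range from 50000 nM to 400000 nM.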

Compound 3, solubility: 110000 nM
Estimate against measurement, compound 3: 1.3-fold (0.10 log units) above; the measured number falls inside the stated range.
By their numbers in this assay, from the lowest: compounds 3 and 2 (each within the scatter of the next); then compound 1.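

In this assay, among the compounds shown here, the step of a 1.5-fold lower number from compound 2 to compound 3 (0.16 log units; within the scatter) gives the first reading of a change at this place, on an aromatic carbon ortho to a chloro group. The group with a six-membered non-aromatic ring with 2 hetero atoms and the group with a five-membered non-aromatic ring with 1 hetero atom are therefore not told apart here. Nothing at hand explains this result. From the compounds shown here alone, compound 1 and compound 2 differ in more than one place, so the part played by the chloro group stays open. Also open, going by these compounds, is how a simple amine or a morpholine would read on this aromatic carbon.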